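The compounds below may be only part of what the source reports. "The series", "measured", "known", "first", "only" and "open" are said of these compounds alone.

Among the measured compounds shown here, compound 1 `COc1ccc(Cl)cc1S(=O)(=O)Nc1cncc(-c2ccccc2C)c1` holds the second highest of the three numbers so far in an assay on isolated protein for inhibition of alkaline phosphatase, tissue-nonspecific isozyme (Homo sapiens) (on this read-out higher numbers stand for weaker inhibition and lower numbers for stronger inhibition), where compound 1 gives 178 nM. Compound 2 `COc1ccc(C#N)cc1S(=O)(=O)Nc1cnc2ccccc2c1` lies well lower, since compound 2 gives 38 nM, while compound 3 `COC(=O)c1ccc(OC)c(S(=O)(=O)Nc2cccnc2)c1` lies far higher, since compound 3 gives 1510 nM; both gaps are beyond the scatter. Compound 4 `CCNC(=O)c1cncc(NS(=O)(=O)c2cc(Cl)ccc2OC)c1` is not yet measured and differs from compound 1 in one place: ethylcarbamoyl in place of 2-methylphenyl on an aromatic carbon. For the measured compounds named here, no single step between measured compounds mirrors this exchange, yet the weakest number so far belongs to compound 3, which also lacks a second carbon ring on its core and gives 1510 nM. The expected step is a 3.7-fold higher number from compound 1 to compound 4 (0.56 log units; beyond the scatter), toward weaker inhibition and beyond the scatter. Compound 4 is thus estimated at 650 nM, between 160 nM and 2600 nM.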

Compound 4, half-maximal inhibitory concentration: 193 nM
Compound 4: middle estimate off by 3.4-fold (0.53 log units), on the high side; low and high end bracket the measured number.
By their numbers in this assay, from the lowest: compound 2; then compounds 1 and 4 (each within the scatter of the next); then compound 3.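

Ethylcarbamoyl in place of 2-methylphenyl gives a 1.1-fold higher number from compound 1 to compound 4 (0.04 log units; within the scatter) in this assay, so at this position on the shared core a group with no ring can stand in for an aromatic carbon ring while the number stays within the scatter. The earlier compounds shown here differ in more than one place and could not show this. Nothing measured here explains why the two groups read alike.

Still open, as far as these compounds go, is how a carboxylic acid, an amine or a dimethylcarbamoyl group would read at this position. A longer chain on the amide nitrogen also remains untested among these compounds.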